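Chloro substitution on the benzamide ring of compound 2

The compounds below may be only part of what the source reports. "The series", "measured", "known", "first", "only" and "open" are said of these compounds alone.

Two members of this series have numbers. Compound 1 `Cc1ccc(C(=O)Nc2cccc(C(F)(F)F)c2)cc1C#Cc1nn(CC2CCN(C)C2)c2ncnc(N)c12` gives 115 nM in a functional assay on MDA-MB-435 cells (Homo sapiens) for antiproliferative activity, read by MTT assay, with a stated time of 72 h (a higher number here means a weaker inhibitor, a lower number a stronger inhibitor), while compound 2 `CN1CCC(n2nc(C#Cc3cccc(C(=O)Nc4cccc(C(F)(F)F)c4)c3)c3c(N)ncnc32)CC1` gives 343 nM. Compound 2 thus carries the highest of the two numbers; the nearest is compound 1, with a lower number beyond the scatter. Compound 3 `CN1CCC(n2nc(C#Cc3cc(C(=O)Nc4cccc(C(F)(F)F)c4)ccc3Cl)c3c(N)ncnc32)CC1` is the next analogue to be tested: the change from compound 2 to compound 3 is chloro in place of hydrogen on an aromatic carbon. Within the data shown here, no step between measured compounds covers this change, so the expectation rests on the spread between the two numbers already seen. A modest step downward is expected, a 2.6-fold lower number from compound 2 to compound 3 (0.42 log units; beyond the scatter), larger than the scatter but not by much. For compound 3 the estimated value in this assay is 130 nM, with a range from 45 nM to 380 nM.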

Compound 3, half-maximal inhibitory concentration: 135 nM
Estimate against measurement, compound 3: 1.0-fold (0.02 log units) below; the range from low to high includes it.
By their numbers in this assay, from the lowest: compounds 1 and 3 (each within the scatter of the next); then compound 2.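

Chloro in place of hydrogen on this aromatic carbon, ortho to a large group and para to a large group, gives in this assay a 2.5-fold lower number from compound 2 to compound 3 (0.40 log units; beyond the scatter) and so marks this position as one where a single-atom change moves the number beyond the scatter. Among these compounds, this is the first step that isolates one change, and it shows that this carbon accepts chloro with no loss of activity in the cells. The data give no measured basis for explaining the step, so it stands as an observation only.

Fluoro, a methoxy group or an amine on the same aromatic carbon would show whether the step is particular to chloro. From the compounds shown here alone, whether chloro brings a similar step when the side chain of compound 1 is present also remains open.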